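This account rests on a few compounds, and the source may have more. Where it says the series, first, only, none or still open, it means among the compounds named here.

Measured compounds:
- compound 1 `CC1(C#Cc2cncc(-c3ccc4c(c3)[C@@]3(COC(N)=N3)c3cc(C5=CCOCC5)ncc3O4)c2)COC1`: 73 mL.min-1.g-1
- compound 2 `NC1=N[C@@]2(CO1)c1cc(NC(=O)c3ccc(Cl)cn3)ccc1Oc1cnc(Cl)cc12`: < 14 mL.min-1.g-1
- compound 3 `CC#Cc1cncc(-c2ccc3c(c2)[C@@]2(COC(N)=N2)c2cc(-c4ccnc(F)c4)ncc2O3)c1`: 20 mL.min-1.g-1

The three compounds share a spiro core and were each measured in an ADME assay on microsomes from liver (Rattus norvegicus) for metabolic stability, read by LC-MS, using NADPH, with a stated time of 30 min, tested at 1 uM; on this read-out lower numbers stand for slow clearance and higher numbers for fast clearance. Compound 1 gives 73 mL.min-1.g-1 in this assay, and compound 3 gives 20 mL.min-1.g-1. Compound 2 stands apart in that its result is a limit, not a number: in this assay compound 2 gives < 14 mL.min-1.g-1, which places it at the limit of < 14 mL.min-1.g-1 in this assay, at which 1 of the 3 values shown sits. Compound 2 therefore sits at the slow-clearance end of the three, with no exact value known.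

The next compound, compound 4 `NC1=N[C@@]2(CO1)c1cc(NC(=O)c3ccc(Cl)cn3)ccc1Oc1cnc(C3CCOCC3)cc12`, has not been measured in this assay. It is compound 2 with a single change: oxan-4-yl in place of chloro on an aromatic carbon. Because compound 2 sits at the limit of < 14 mL.min-1.g-1 in this assay, at which 1 of the 3 values shown sits, there is no room for compound 4 to appear slower than compound 2; any detectable difference would run toward faster clearance. Starting from a limit, the expected step is small to modest in that direction. Compound 4 is estimated at 25 mL.min-1.g-1, with a plausible range from 10 mL.min-1.g-1 to 60 mL.min-1.g-1, which would mean an expected step of an at least 1.7-fold higher number from compound 2 to compound 4 (0.25 log units; that floor lies within the scatter).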

Compound 4, intrinsic clearance in microsomes: 79 mL.min-1.g-1
Estimate against measurement, compound 4: 3.2-fold (0.50 log units) below; the measured number lies above the stated range.
By their numbers in this assay, from the lowest: compound 3; then compounds 1 and 4 (each within the scatter of the next). At a limit, below all of these: compound 2.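

In this assay, among the compounds shown here, putting oxan-4-yl in place of chloro on this aromatic carbon, next to the ring nitrogen, gives the first single change that can be read: an at least 5.6-fold higher number from compound 2 to compound 4 (0.75 log units; beyond the scatter). The earlier compounds shown here could not show this, since no two of them differed in one place; now it is clear that, on the core of compound 2, what this position carries matters for clearance in this read-out. Compound 2 stands at a limit and not at an exact number, so the step gives only the smallest size this change can have: the limit of < 14 mL.min-1.g-1 in this assay, at which 1 of the 4 values shown sits.

The values alone do not tell which feature of the oxan-4-yl group goes with the higher number, whether the ring, its oxygen or its larger size. Going by these compounds, it also stays open whether a smaller group on the same carbon, such as methyl or an amine, or a ring with nitrogen in place of the oxygen, such as piperidin-4-yl, would give a number closer to that of compound 2 or to that of compound 4.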